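The compounds below may be only part of what the source reports. "The series", "measured", "known", "first", "only" and "open" are said of these compounds alone.

Compound 1 `Cc1ccc2nc(NC(=O)CNC(=O)c3nn(-c4ccccc4)c(=O)c4ccccc34)sc2c1`: in an assay on L cells for inhibition of Protein-serine O-palmitoleoyltransferase porcupine (Mus musculus), read by reporter gene assay, with a stated time of 24 h (on this read-out lower numbers stand for an effect already at smaller amounts and higher numbers for an effect only at larger amounts of compound), compound 1 gives 35 nM.
Compound 2 `O=C(CNC(=O)c1nn(-c2ccc(F)cc2)c(=O)c2ccccc12)Nc1nc2ccccc2s1`: in this assay compound 2 gives only > 25000 nM, which is a limit of the assay and not a number.

Compound 2 therefore stands at the limit of > 25000 nM in this assay, at which 1 of the 2 values shown sits. Going by the values given here, compound 1 has a measured number; the two differ in two places, so their values show only that the pair spans a wide gap. Compound 3 `Cc1ccc2nc(NC(=O)CNC(=O)c3nn(-c4ccc(F)cc4)c(=O)c4ccccc34)sc2c1` arises from compound 2 through (methyl in place of hydrogen on an aromatic carbon), methyl in place of hydrogen on an aromatic carbon. Among the compounds with values here, no measured step covers this change. Compound 3 is expected to move toward a measurable value, by a step of an at least 16-fold lower number from compound 2 to compound 3 (1.22 log units; beyond the scatter). Compound 3 is estimated at 1500 nM, between 100 nM and 25000 nM.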

Compound 3, half-maximal effective concentration: 100 nM
For compound 3 the middle estimate is 15-fold (1.18 log units) above the measured one; the measured number falls inside the stated range.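

Methyl in place of hydrogen on an aromatic carbon, turning 1,3-benzothiazol-2-yl into 6-methyl-1,3-benzothiazol-2-yl, is the only change behind an at least 250-fold lower number from compound 2 to compound 3 (2.39 log units; beyond the scatter) in this assay. The value of compound 2 is a limit of the assay and not a number: the limit of > 25000 nM in this assay, at which 1 of the 3 values shown sits. With this methyl in place, adding a fluoro group gives a much smaller step, a 2.9-fold higher number from compound 1 to compound 3 (0.46 log units; beyond the scatter).

The compounds shown leave open whether ethyl, methoxy, chloro or an amine at this position would serve as well as methyl.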